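Tert-butylphenyl in place of pyridin-2-yl on the anilino nitrogen

The source may hold more compounds than are shown below. What is called first, only, known or untested is meant among the compounds shown, and "the series" means these compounds.

This account follows one change on an anilino-substituted imide core. Three compounds have numbers in an assay on FRT-Jurkat cells for inhibition of nuclear factor NF-kappa-B complex (Homo sapiens), read by flow cytometry, with a stated time of 24 h, tested at 10 uM; on this read-out lower numbers stand for less inhibition and higher numbers for more inhibition at the one concentration tested (going by the name of the read-out). Compound 1 `O=C1CCC(N2C(=O)c3ccc(Nc4ccccn4)cc3C2=O)C(=O)N1` gives 9%, the lowest of the three; compound 2 `COc1ccc(Nc2cccc3c2C(=O)N(C2CCC(=O)NC2=O)C3=O)cc1` gives 13%, within the scatter of compound 1, and compound 3 `CC(C)(C)c1ccc(Nc2cccc3c2C(=O)N(C2CCC(=O)NC2=O)C3=O)cc1` gives 36%, beyond the scatter above compound 1. Among the compounds with values here, the one step between compounds that differ in a single place is a number 23 percentage points higher from compound 2 to compound 3 (beyond the scatter), a modest rise.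

Compound 4 `CC(C)(C)c1ccc(Nc2ccc3c(c2)C(=O)N(C2CCC(=O)NC2=O)C3=O)cc1` is not yet measured. It differs from compound 1 by 4-(tert-butyl)phenyl in place of pyridin-2-yl on a nitrogen on an aromatic ring. Within the data shown here, the step from compound 2 to compound 3 bears on this change in part, since it also brings in a tert-butyl-bearing aryl group, though the core of compounds 2 and 3 is not the shared core of compounds 1 and 4, and no measured pair exchanges a pyridin-2-yl group. A modest rise is therefore expected, a number 16 percentage points higher from compound 1 to compound 4 (beyond the scatter), with wide uncertainty. Compound 4 is estimated at 25%, expected between 5% and 50%.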

Compound 4, a percentage reported as inhibition, at one concentration (the size of the read-out at that concentration, not a potency): 17%
Beside the measured number, compound 4's estimate is 8 percentage points above it; the measured number falls inside the stated range.
By their numbers in this assay, from the lowest: compounds 1, 2 and 4 (each within the scatter of the next); then compound 3.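

In this assay, 4-(tert-butyl)phenyl in place of pyridin-2-yl on the nitrogen gives a number 8 percentage points higher from compound 1 to compound 4 (within the scatter), so at the one concentration tested the two groups cannot be told apart on the shared core. Within the data shown here, this is the first measured exchange of pyridin-2-yl, and it shows that a tert-butyl-bearing aryl group on this nitrogen does not by itself bring a step beyond the scatter, unlike the tert-butyl for methoxy exchange on another core, a number 23 percentage points higher from compound 2 to compound 3 (beyond the scatter). No evidence at hand explains why these two steps differ in size.

Still open, from the compounds shown here alone, is whether a carboxylic acid or a dimethylamino group on the same aryl ring would move the number beyond the scatter. Also open, going by these compounds, is how pyridin-2-yl would read on the core of compound 3.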